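Chloro for methyl on the core: compound 3 to compound 4

The source may hold more compounds than are shown below. What is called first, only, known or untested is meant among the compounds shown, and "the series" means these compounds.

Measured so far in an assay on isolated protein for displacement of a labelled ligand from metabotropic glutamate receptor 5 (Homo sapiens), with a stated time of 60 min, tested at 1 uM; a lower number here means less inhibition, a higher number more inhibition at the concentration tested (going by the name of the read-out):
compound 1 `CC1CCN(c2c(S(=O)(=O)c3ccccc3)cnc3ccc(Cl)cc23)CC1` gives 59%
compound 2 `COc1cccc(S(=O)(=O)c2cnc3ccc(Cl)cc3c2N2CCC(C)CC2)c1` gives 87%
compound 3 `Cc1ccc2ncc(S(=O)(=O)c3cccc(F)c3)c(N3CCC(C)CC3)c2c1` gives 94%

Compound 3 has the highest of the three numbers; compound 2 lies within the scatter of it, while compound 1 sits well below both. Compound 4 `CC1CCN(c2c(S(=O)(=O)c3cccc(F)c3)cnc3ccc(Cl)cc23)CC1` differs from compound 3 by chloro in place of methyl on an aromatic carbon. Going by the values given here, the only single step measured, a number 28 percentage points higher from compound 1 to compound 2 (beyond the scatter), concerns the phenyl ring on the sulfonyl group, not the core; no measured step touches the chloro-for-methyl change, and compounds 1 and 3 differ in two places at once. With nothing bearing on it, the step of a number 8 percentage points lower from compound 3 to compound 4 (within the scatter) is expected to stay within the scatter. Compound 4 is therefore estimated at 86%, with a range of 66% to 98%.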

Compound 4, a percentage reported as inhibition, at one concentration (the size of the read-out at that concentration, not a potency): 58%
Beside the measured number, compound 4's estimate is 28 percentage points above it; the measured number lies below the stated range.
By their numbers in this assay, from the lowest: compounds 4 and 1 (each within the scatter of the next); then compounds 2 and 3 (each within the scatter of the next).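

Chloro in place of methyl on an aromatic carbon of the core gives a number 36 percentage points lower from compound 3 to compound 4 (beyond the scatter) in this assay, so this position strongly affects the read-out with the fluoro-bearing phenyl ring held constant. On the chloro core, fluoro in place of hydrogen gives a number 1 percentage points lower from compound 1 to compound 4 (within the scatter), whereas fluoro in place of methoxy gives a number 29 percentage points lower from compound 2 to compound 4 (beyond the scatter), so among these three compounds only methoxy stands apart. No measurement shown accounts for the effect of the core change.

Going by these compounds, whether methoxy would behave the same way on the methyl core remains open. So does how a nitrile or an amine at the core position would compare with methyl and chloro.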